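Cytotoxicity limits across urea-linked analogues of compound 1

The source may report more compounds than this note shows. Statements on the series, on what has been measured and on what is new or still open speak of the compounds shown alone.

Compound 1 `O=C(Nc1cccc(-n2cc(-c3ccncc3)c(-c3ccc(Cl)c(O)c3)n2)c1)Nc1cccc(C(F)(F)F)c1` gives > 32500 nM in a functional assay on ACHN cells (Homo sapiens) for inhibition, read by sulforhodamine B assay, with a stated time of 48 h (on this read-out lower numbers stand for higher toxicity in this test and higher numbers for lower toxicity in this test), a limit of the test.
Compound 2 `O=C(Nc1cccc(-n2cc(-c3ccncc3)c(-c3ccc(Cl)c(O)c3)n2)c1)Nc1ccc(Cl)c(Cl)c1` gives > 32500 nM in this assay, again a limit.
Compound 3 `COc1cc(-c2nn(-c3cccc(NC(=O)Nc4cccc(C(F)(F)F)c4)c3)cc2-c2ccncc2)ccc1Cl` gives > 50000 nM in this assay, also a limit.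

All three measured values are limits, so compound 1 stands at the ceiling of the numbers shown rather than at a number of its own; two of the three sit at the limit of > 32500 nM in this assay, at which 2 of the 3 values shown sit, and one at the limit of > 50000 nM in this assay, at which 1 of the 3 values shown sits. Compound 4 `O=C(Nc1cccc(-n2cc(-c3ccncc3)c(-c3ccc(Cl)c(O)c3)n2)c1)Nc1cc(C(F)(F)F)cc(C(F)(F)F)c1` carries trifluoromethyl in place of hydrogen on an aromatic carbon. The step from compound 1 to compound 2 a step that the two limits leave unreadable from compound 1 to compound 2 exchanges the same aryl urea terminus and is unreadable, and the step from compound 1 to compound 3 a step that the two limits leave unreadable from compound 1 to compound 3 is likewise unreadable. Within the data shown here, neither step therefore gives a readable size to carry over, and no measured step reports a direction for adding a second trifluoromethyl. The expectation for compound 4 is that this assay will again return a limit, with a step that the limit leaves unreadable from compound 1 to compound 4 expected relative to compound 1. Compound 4 is estimated at 40000 nM, with a range from 15000 nM to 100000 nM.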

Compound 4, concentration lethal to 50% of the cells: 17300 nM
The estimate for compound 4 lay 2.3-fold (0.36 log units) above the measured number; the measured number falls inside the stated range.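

Compound 4 is the only compound shown with a number of its own rather than a limit: in this assay compound 4 gives 17300 nM. Trifluoromethyl in place of hydrogen on an aromatic carbon, meta to a trifluoromethyl group, gives an at least 1.8-fold lower number from compound 1 to compound 4 (0.27 log units; that floor lies within the scatter), so this position is the first in the series to give a readable step, though only its floor is known and that floor does not clear the scatter. The other steps shown cannot be read, and the other values remain limits: the limit of > 32500 nM in this assay, at which 2 of the 4 values shown sit.

From the compounds shown here alone, it remains open whether the lower number is specific to trifluoromethyl at this position or would also appear with an amine or a carboxylic acid there. Going by these compounds, it is equally open whether the same change would give a readable step on the methyl ether of compound 3.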